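The source may report more compounds than this note shows. Statements on the series, on what has been measured and on what is new or still open speak of the compounds shown alone.

Compound 1 `Cc1ccc(C(=O)Nc2cc(-c3ccccc3)nn2-c2ccccc2)cc1` gives 64 nM in a functional assay on cells for positive allosteric modulation of metabotropic glutamate receptor 5 (Rattus norvegicus), read by calcium flux; on this read-out lower numbers stand for an effect already at smaller amounts and higher numbers for an effect only at larger amounts of compound. Compound 2 `O=C(Nc1cc(-c2ccccc2)nn1-c1ccccc1)c1cc([N+](=O)[O-])cc([N+](=O)[O-])c1` gives 65 nM in this assay, a number that sits inside the scatter of compound 1, so the two are indistinguishable; compound 1 formally carries the lower of the two figures, but that ordering means nothing here. Among the measured compounds shown here, no step between the two measured compounds is counted as such, and they already differ in the group on the carbonyl carbon.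

Compound 3 `COc1cc(OC)cc(C(=O)Nc2cc(-c3ccccc3)nn2-c2ccccc2)c1` is not yet measured. From compound 1 it differs by 3,5-dimethoxyphenyl in place of 4-methylphenyl on a carbonyl carbon. Since compounds 1 and 2 show that a change of the aryl group on the carbonyl left the number where it was, the step from compound 1 to compound 3 in this assay is expected to be small, a 1.3-fold higher number from compound 1 to compound 3 (0.10 log units; within the scatter), with no direction beyond the scatter. Compound 3 is therefore estimated at 80 nM, in a range of 25 nM to 300 nM.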

Compound 3, half-maximal effective concentration: 2040 nM
Compound 3: the middle estimate sits 26-fold (1.41 log units) below what was measured, outside the stated range (above it).
By their numbers in this assay, from the lowest: compounds 1 and 2 (each within the scatter of the next); then compound 3.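

The aryl group on this carbonyl carbon does not tolerate every change: in this assay, 3,5-dimethoxyphenyl in place of 4-methylphenyl gives a 32-fold higher number from compound 1 to compound 3 (1.50 log units; beyond the scatter) and so shows that this position can strongly move the number, which compounds 1 and 2 alone gave no sign of. Two groups on the aryl ring do not by themselves go with a high number, since compound 2, with its two nitro groups, gives 65 nM in this assay and stays within the scatter of compound 1. Nothing available here accounts for the step.

Going by these compounds, whether the step belongs to the methoxy groups as such or to their number stays open. Also open, on these data alone, is what a single methoxy group, a hydroxyl or a dimethylamino group on this aryl ring would give.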